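The source may report more compounds than this note shows. Statements on the series, on what has been measured and on what is new or still open speak of the compounds shown alone.

The series compared in a functional assay on MIA PaCa-2 cells (Homo sapiens) for inhibition, read by MTT assay, with a stated time of 72 h (a higher number here means a weaker inhibitor of growth, a lower number a stronger inhibitor of growth), is small. Compound 1 `O=S(=O)(NCCCNCC1COc2ccccc2O1)c1cc(C(F)(F)F)cc(C(F)(F)F)c1` gives 2600 nM in this assay. Compound 2 `CN(CCCNS(=O)(=O)c1cc(C(F)(F)F)cc(C(F)(F)F)c1)Cc1ccccc1` gives 33000 nM, the higher of the two numbers recorded; its nearest neighbour is compound 1, whose lower number sits well beyond the scatter, so compound 2 is the weaker inhibitor of growth of the pair. Compound 3 `COc1ccc(CNCCCNS(=O)(=O)c2cc(C(F)(F)F)cc(C(F)(F)F)c2)cc1` has not yet been measured. It differs from compound 2 in one place: (4-methoxybenzyl)amino in place of benzyl(methyl)amino on a saturated chain carbon, three bonds along the chain from a sulfonamide nitrogen. Within the data shown here, with no step between measured compounds that isolates this exact change, the expectation rests on the two values at hand, and compound 1, which also carries a secondary amine on the same chain, gives the lower number. Compound 3 is therefore expected to move toward a lower number by a 3.7-fold lower number from compound 2 to compound 3 (0.56 log units; beyond the scatter). The estimate for compound 3 in this assay is 9000 nM, with a range from 2500 nM to 30000 nM.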

Compound 3, concentration for 50% growth inhibition: 2500 nM
Estimate against measurement, compound 3: 3.6-fold (0.56 log units) above, within the range that was stated.
By their numbers in this assay, from the lowest: compounds 3 and 1 (each within the scatter of the next); then compound 2.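

In this assay, the change at this saturated chain carbon, three bonds along the chain from a sulfonamide nitrogen, produces a large step (a 13-fold lower number from compound 2 to compound 3 (1.12 log units; beyond the scatter)), so this position clearly affects the read-out. The step to (4-methoxybenzyl)amino also introduces the methoxy group and leaves a hydrogen on the amine nitrogen, and this one comparison cannot separate those two differences. With 4-methoxyphenyl in place of 2,3-dihydro-1,4-benzodioxin-2-yl on a saturated chain carbon bound to an amine nitrogen, the values stay within the scatter (a 1.0-fold lower number from compound 1 to compound 3 (0.02 log units; within the scatter)), and nothing at hand accounts for either result.

From the compounds shown here alone, it remains open whether a plain benzylamino group would read like compound 2 or compound 3. Going by these compounds, the effect of a (4-methoxybenzyl)(methyl)amino group or a longer chain also remains unknown.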